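From Compound 1 to Compound 4 in Cell Tolerance

The compounds below may be only part of what the source reports. "The series", "measured", "known", "first", "only" and "open" are said of these compounds alone.

Compound 1 `CN1CCN(c2nc(NCC(=O)NCc3ccccc3)c3ccccc3n2)CC1` was examined in an ADME assay on HEK-293T cells (Homo sapiens) for cytotoxicity, read by CCK-8 assay, with a stated time of 48 h; a higher number here means that more compound is tolerated, a lower number that less compound is tolerated. In this assay compound 1 reaches only the limit of the assay, at > 100000 nM. Compound 2 `CCOc1ccc(NC(=O)CSc2c[nH]c3ccc(Br)cc23)cc1` gives 44000 nM in this assay. Compound 3 `CCN(CC)c1nc(SCC(=O)NCc2ccccc2)c2ccccc2n1` also sits at the limit of the assay in this assay, with > 100000 nM. Compound 1 thus stands at the limit of > 100000 nM in this assay, at which 2 of the 3 values shown sit, which it shares with compound 3, while compound 2 is the only one of the three to give a number rather than a limit.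

Compound 4 `CCN(CC)c1nc(NCC(=O)NCc2ccccc2)c2ccccc2n1` has not yet been measured in this assay. It differs from compound 1 in one place: diethylamino in place of 4-methylpiperazin-1-yl on an aromatic carbon. Within the data shown here, no pair of measured compounds carries this exact change, so the size of the step cannot be read from measured values. Compound 3 bears the same diethylamino group, and in this assay compound 3 gives a limit, > 100000 nM. On that basis compound 4 is expected to be tolerated up to a similar limit, with no step beyond the scatter. Compound 4 is estimated at 100000 nM, between 50000 nM and 300000 nM. The step that this estimate means is a number no higher from compound 1 to compound 4 (the limit leaves the size open), expected to lie within the scatter.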

Compound 4, half-maximal cytotoxic concentration: > 100000 nM
Compound 4: no number, only a limit; the forecaster's own chance of this, stated with the estimate: 75%; the middle value sits exactly at the limit.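

In this assay compound 4 gives > 100000 nM, a limit of the assay and not a number. Compound 1 likewise gives only a limit, > 100000 nM, so no step can be read between compound 1 and compound 4. The compounds shown leave open whether diethylamino in place of 4-methylpiperazin-1-yl changes the tolerated concentration in this assay at all.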